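Biaryl amide series: methyl to fluoro on the pyridine

The source may hold more compounds than are shown below. What is called first, only, known or untested is meant among the compounds shown, and "the series" means these compounds.

Measured compounds:
compound 1 `Cc1cccnc1-c1ccc(C(=O)Nc2ccc(Cl)cc2)cc1` 2020 nM
compound 2 `Cc1cccnc1-c1ccc(C(=O)Nc2ccc(C(C)(C)C)cc2)cc1` 9 nM

In a functional assay for antagonist activity at transient receptor potential cation channel subfamily V member 1 (Rattus norvegicus) (a lower number here means a stronger inhibitor, a higher number a weaker inhibitor), compound 1 gives 2020 nM and compound 2 gives 9 nM. For the measured compounds named here, the only measured step is a 220-fold lower number from compound 1 to compound 2 (2.35 log units; beyond the scatter), tert-butyl in place of chloro on an aromatic carbon. Compound 2 therefore holds the lowest of the two numbers in this assay.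

Compound 3 `CC(C)(C)c1ccc(NC(=O)c2ccc(-c3ncccc3F)cc2)cc1` differs from compound 2 by fluoro in place of methyl on an aromatic carbon. Going by the values given here, no measured step touches the pyridine substituent; the one known step concerns the other end of the shared core and gives no guide here. Both compounds keep the tert-butyl that carried the large gain from compound 1 to compound 2. Compound 3 is therefore expected to stay close to compound 2, with at most a modest drift to a higher number, a 2.2-fold higher number from compound 2 to compound 3 (0.35 log units; beyond the scatter), likely within or near the scatter. The estimate for compound 3 in this assay is 20 nM, range 5 nM to 80 nM.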

Compound 3, half-maximal inhibitory concentration: 1 nM
The estimate for compound 3 lay 20-fold (1.30 log units) above the measured number, outside the stated range (below it).
By their numbers in this assay, from the lowest: compound 3; then compound 2; then compound 1.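

In this assay, the change from 3-methylpyridin-2-yl to 3-fluoropyridin-2-yl gives a 9.0-fold lower number from compound 2 to compound 3 (0.95 log units; beyond the scatter), so the read-out responds to this position as well as to the tert-butyl end of the series. This step is smaller than a 220-fold lower number from compound 1 to compound 2 (2.35 log units; beyond the scatter), but with the tert-butyl held constant it still places compound 3 lowest of the three in this assay. Nothing at hand accounts for the gain from fluoro in place of methyl.

As far as these compounds go, only methyl and fluoro are compared at this position, so it remains open how a hydrogen, a chloro, a methoxy or a trifluoromethyl there would compare. From the compounds shown here alone, it is also open whether the same change would give a similar step with the chloro of compound 1 in place of the tert-butyl.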